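The compounds below may be only part of what the source reports. "The series", "measured", "known", "first", "only" and "open" are said of these compounds alone.

Measured in an ADME assay on Vero cells (Chlorocebus sabaeus) for cytotoxicity, read by MTT assay, with a stated time of 72 h; a higher number here means that more compound is tolerated, a lower number that less compound is tolerated:
compound 1 `O=C(/C=C/c1ccc(O)cc1)Nc1nnc(-c2ccccc2)[nH]1` gives 1850000 nM;
compound 2 `O=C(/C=C/c1cccc([N+](=O)[O-])c1)Nc1nnc(-c2ccccc2)[nH]1` gives 1990000 nM;
compound 3 `O=C(/C=C/c1ccc2c(c1)COC2)Nc1nnc(-c2ccccc2)[nH]1` gives 1820000 nM.

Compound 1 sits alongside compounds 2 and 3: its gaps to both lie within the scatter, so the three numbers cannot be told apart. Going by the values given here, no pair of measured compounds differs in a single place, so nothing calibrates one change on its own. Compound 4 `COc1ccc(/C=C/C(=O)Nc2nnc(-c3ccccc3)[nH]2)cc1` differs from compound 1 by methyl in place of hydrogen on an oxygen on an aromatic ring. Since three rather different substituents all return indistinguishable numbers in this assay, a small change of this kind is expected to leave the number where it is: the expected step of no change at the digits printed from compound 1 to compound 4 (within the scatter) is flat, with no movement beyond the scatter in either direction. Compound 4 is estimated at 1850000 nM, with a range of 1000000 nM to 3500000 nM.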

Compound 4, half-maximal cytotoxic concentration: 1280000 nM
Compound 4: the middle estimate sits 1.4-fold (0.16 log units) above what was measured, and the stated range covers the measured number.
By their numbers in this assay, from the lowest: compounds 4, 3, 1 and 2 (each within the scatter of the next).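

Hydroxy to methoxy is the first single-place change that can be read in the series, and it gives a 1.4-fold lower number from compound 1 to compound 4 (0.16 log units; within the scatter). In this assay, replacing hydrogen with methyl on this oxygen therefore produces no difference that can be told from the scatter. No measurement available here offers an explanation for this result.

On these data alone, whether a longer chain on the oxygen, such as ethoxy, would also stay within the scatter remains open. So does the outcome of replacing the hydroxy with an amine or a carboxylic acid.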